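A few compounds are considered here, and "the series" means these few. Any claim that something is new, unique, unknown or untested is made for them only; others in the source may bear on it.

Compound 1 `Cc1cc(Sc2ccc(Cl)cc2)cn2c(CSCCc3ccccc3)cnc12` and compound 2 `Cc1cc(Sc2ccc(O)cc2)cn2c(CSCCc3ccccc3)cnc12` share one core; compound 3 `Cc1cc(Sc2ccc(Cl)cc2)c2ncc(CSCCc3ccccc3)n2c1` is built from the same atoms joined differently, and the difference between the two cores is not broken down here. In an ADME assay on HEL cells (Homo sapiens) for cytotoxicity, with a stated time of 3 days (a higher number here means that more compound is tolerated, a lower number that less compound is tolerated), compound 1 gives 20 ug/mL, compound 2 gives 4 ug/mL, and compound 3 gives 4 ug/mL. The change hydroxy in place of chloro on an aromatic carbon produced a 5.0-fold lower number from compound 1 to compound 2 (0.70 log units; beyond the scatter). Compound 4 `Cc1cc(Sc2ccc(O)cc2)c2ncc(CSCCc3ccccc3)n2c1` carries the same change on the core of compound 3, (hydroxy in place of chloro on an aromatic carbon), at the same place in the same words. Among the measured compounds shown here, for compound 4 a step of about the same size is expected, a 5.0-fold lower number from compound 3 to compound 4 (0.70 log units; beyond the scatter), resting on compound 1 and compound 2, because a 5.0-fold lower number from compound 1 to compound 2 (0.70 log units; beyond the scatter) is the only measured instance of this change. Compound 4 is therefore estimated at 0.8 ug/mL, within 0.4 ug/mL to 2 ug/mL.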

Compound 4, minimum cytotoxic concentration: > 100 ug/mL
Compound 4: a limit, no number; the forecaster's own chance of this, stated with the estimate: 5%; middle value at least 120-fold (2.09 log units) away from the limit.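

In this assay, hydroxy in place of chloro on an aromatic carbon gives an at least 25-fold higher number from compound 3 to compound 4 (1.39 log units; beyond the scatter), so in this pair of cores the change does not carry over, even in direction: the same change on two cores in this assay, a 5.0-fold lower number (0.70 log units; beyond the scatter) from compound 1 to compound 2 and an at least 25-fold higher number (1.39 log units; beyond the scatter) from compound 3 to compound 4, at least 120-fold (2.09 log units) apart, beyond the scatter of two such steps. For compound 4, > 100 ug/mL is a limit of the assay and not a number: the limit of > 100 ug/mL in this assay, at which 1 of the 4 values shown sits. With one pair on each core, this shows that the step depends on the core here, but it does not show why, or which core's step is the more typical of the series.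

As far as these compounds go, it remains open whether other groups at the same place, such as an amine or a carboxylic acid, would also differ between the two cores. From the compounds shown here alone, the size of the step from compound 3 to compound 4 also remains open beyond its limit.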